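This account rests on a few compounds, and the source may have more. Where it says the series, first, only, none or still open, it means among the compounds named here.

Among the compounds with values here, compound 1 `CCCCc1ccc2ncc(-c3nn[nH]n3)cc2c1` and compound 2 `COc1ccc(OC)c2c(=O)c(-c3nn[nH]n3)c[nH]c12` are the two compounds measured so far. In a functional assay on the whole organism (strain Sprague-Dawley) for inhibition, with Rattus norvegicus as the target (a higher number here means that more compound is needed for the effect, a lower number that less compound is needed), compound 1 gives 5 mg/kg, the highest of the two numbers. In this assay compound 2 gives 1.25 mg/kg, a lower number by a margin beyond the usual scatter. Compound 3 `c1cc2ncc(-c3nn[nH]n3)cc2cc1OC1CCCCC1` has not yet been measured in this assay. It differs from compound 1 by cyclohexyloxy in place of butyl on an aromatic carbon. Within the data shown here, no step between measured compounds involves this change, and compound 2 shares neither the core of compound 1 nor the group that leaves or enters, so nothing measured points to a direction for the change. The step is therefore expected to be small and without a clear direction beyond the scatter, estimated as no change at the digits printed from compound 1 to compound 3 (within the scatter). Compound 3 is expected to give 5 mg/kg in this assay, with a range from 1.5 mg/kg to 15 mg/kg.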

Compound 3, minimum effective dose: 5 mg/kg
Estimate against measurement, compound 3: no gap at the digits printed; measured number inside the range.
By their numbers in this assay, from the lowest: compound 2; then compounds 1 and 3 (each within the scatter of the next).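

In this assay, replacing butyl with cyclohexyloxy on this aromatic carbon gives no change at the digits printed from compound 1 to compound 3 (within the scatter). On the core of compound 1, this position therefore takes a group with more heavy atoms, a six-membered non-aromatic ring and a hydrogen-bond acceptor, with no shift beyond the scatter. Nothing available explains why the two groups read alike.

This single step cannot show whether the oxygen and the ring each leave the number unchanged or whether their separate contributions offset each other. It also leaves open whether an amine, a carboxylic acid or a longer chain at this position would move the number beyond the scatter, and whether any such group could approach the lower number of compound 2, which gives 1.25 mg/kg.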